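The source may hold more compounds than are shown below. What is called first, only, known or untested is meant among the compounds shown, and "the series" means these compounds.

Measured compounds:

Compound 1 `COc1ccc2nc(-c3ccc(-n4c(C)ccc4-c4ccc(F)cc4)cc3)sc2c1`: 13800 nM
Compound 2 `COc1ccc(-c2ccc(C)n2-c2ccc(-c3nc4ccc(OC)cc4s3)cc2)cc1`: 12700 nM
Compound 3 `COc1cc2nc(-c3ccc(-n4c(C)ccc4-c4ccc(F)cc4)cc3)sc2c(OC)c1OC`: 13100 nM

All three were tested in a functional assay on MDA-MB-231 cells (Homo sapiens) for cytotoxicity, read by MTT assay, with a stated time of 72 h; a higher number here means a weaker inhibitor, a lower number a stronger inhibitor. Compound 1 and compound 2 differ by methoxy in place of fluoro on an aromatic carbon, and that change made a step of a 1.1-fold lower number from compound 1 to compound 2 (0.04 log units; within the scatter). Compound 3 carries a different core from compound 1; the difference between the two cores is not broken down here, and the values of the two compounds lie close to each other.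

Compound 4 `COc1ccc(-c2ccc(C)n2-c2ccc(-c3nc4cc(OC)c(OC)c(OC)c4s3)cc2)cc1` has not yet been measured. It differs from compound 3 by methoxy in place of fluoro on an aromatic carbon, the same change that separates compound 1 from compound 2. Since that earlier change gave a 1.1-fold lower number from compound 1 to compound 2 (0.04 log units; within the scatter), a step of about a 1.0-fold lower number from compound 3 to compound 4 (0.02 log units; within the scatter) is expected from compound 3 to compound 4 in this assay. Because compound 3 gives 13100 nM, compound 4 is estimated at 12500 nM, expected to fall between 6500 nM and 25000 nM.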

Compound 4, half-maximal inhibitory concentration: 12500 nM
Compound 4: the middle estimate sits on the measured number at the digits printed; measured number inside the range.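

In this assay, the change from 4-fluorophenyl to 4-methoxyphenyl made a step of a 1.0-fold lower number from compound 3 to compound 4 (0.02 log units; within the scatter). Set beside the earlier case, the change reads the same on both cores: the same change on two cores in this assay, a 1.1-fold lower number (0.04 log units; within the scatter) from compound 1 to compound 2 and a 1.0-fold lower number (0.02 log units; within the scatter) from compound 3 to compound 4, 1.0-fold (0.02 log units) apart, within the scatter of two such steps

This shows that, on these two cores, the change leaves the number within the scatter; it does not show that it would do so on any other core, nor whether a larger step would carry across in the same way.

The compounds shown leave open what other groups in this place, such as an amine or a carboxylic acid, would do to the number. They also leave open whether the change would read the same in another assay.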